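Removing both hydroxyl groups from the amide side chain

The compounds below may be only part of what the source reports. "The series", "measured", "known", "first", "only" and "open" are said of these compounds alone.

Of the compounds shown here, three sharing one core have been tested in an assay on isolated protein for inhibition of alkaline phosphatase, tissue-nonspecific isozyme (Homo sapiens); on this read-out higher numbers stand for weaker inhibition and lower numbers for stronger inhibition. Compound 1 `O=C(NCCCCO)c1cc(-c2ccc(Cl)cc2Cl)n[nH]1` gives 35 nM, compound 2 `COCCNC(=O)c1cc(-c2ccc(Cl)cc2Cl)n[nH]1` gives 46 nM, and compound 3 `O=C(c1cc(-c2ccc(Cl)cc2Cl)n[nH]1)N(CCO)CCO` gives 47 nM. Compound 3 stands among these without separation: a 1.3-fold higher number from compound 1 to compound 3 (0.13 log units; within the scatter) and a 1.0-fold higher number from compound 2 to compound 3 (0.01 log units; within the scatter). Compound 4 `CCN(CC)C(=O)c1cc(-c2ccc(Cl)cc2Cl)n[nH]1` differs from compound 3 by diethylamino in place of bis(2-hydroxyethyl)amino on a carbonyl carbon. The steps seen so far bear on this change only loosely, since each swapped one side chain for another and each stayed within the scatter, including a 1.3-fold higher number from compound 1 to compound 2 (0.12 log units; within the scatter). The expectation for compound 4 is therefore no step beyond the scatter, expressed as a 1.1-fold higher number from compound 3 to compound 4 (0.03 log units; within the scatter) in this assay. Compound 4 is estimated at 50 nM, with a range from 20 nM to 130 nM.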

Compound 4, half-maximal inhibitory concentration: 285 nM
For compound 4 the middle estimate is 5.7-fold (0.76 log units) below the measured one; measured number outside the range, above it.
By their numbers in this assay, from the lowest: compounds 1, 2 and 3 (each within the scatter of the next); then compound 4.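

For the compounds shown here, the amide side chain does affect this number: diethylamino in place of bis(2-hydroxyethyl)amino gives the first step here beyond the scatter (a 6.1-fold higher number from compound 3 to compound 4 (0.78 log units; beyond the scatter)). The other two side chains show similar gaps (a 6.2-fold higher number from compound 2 to compound 4 (0.79 log units; beyond the scatter); an 8.1-fold higher number from compound 1 to compound 4 (0.91 log units; beyond the scatter)), so compound 4, whose side chain has no oxygen, stands apart from compound 1, compound 2 and compound 3, whose side chains all carry oxygen. No measurement here explains this gap. Still open, from the compounds shown here alone, is whether a single hydroxyl on one ethyl arm would close the gap, or whether an amine or a carboxylic acid at the chain end would do the same.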